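This account rests on a few compounds, and the source may have more. Where it says the series, first, only, none or still open, it means among the compounds named here.

The series shares one core, first shown in compound 1 `CCn1c(C(=O)NCCN(C)C)ccc1C(CC)(CC)c1ccc(OCCC(O)(CC)CC)c(C)c1`, which in a functional assay on HepG2 cells (Homo sapiens) for antiproliferative activity, read by MTT assay, with a stated time of 48 h (a higher number here means a weaker inhibitor, a lower number a stronger inhibitor), gives 240 nM. For the measured compounds named here, compound 2 `CCC(C)C(NC(=O)c1ccc(C(CC)(CC)c2ccc(OCCC(O)(CC)CC)c(C)c2)n1CC)C(=O)O` gives 2620 nM in this assay, the highest of the two numbers recorded so far; its only neighbour is compound 1, and the change between them, 1-carboxy-2-methylbutyl in place of 2-(dimethylamino)ethyl on an amide-type nitrogen, brought an 11-fold higher number from compound 1 to compound 2 (1.04 log units; beyond the scatter). Compound 3 `CCn1c(C(=O)NC(C)CO)ccc1C(CC)(CC)c1ccc(OCCC(O)(CC)CC)c(C)c1` has not yet been measured in this assay. It differs from compound 2 in one place: 1-(hydroxymethyl)ethyl in place of 1-carboxy-2-methylbutyl on an amide-type nitrogen. Going by the values given here, the only measured step that bears on this position is the one from compound 1 to compound 2, which was large; it shows that the group on the amide-type nitrogen matters and that the 1-carboxy-2-methylbutyl group gave the higher number. Exchanging that group for 1-(hydroxymethyl)ethyl is therefore expected to move the number back toward that of compound 1, though nothing in the data says it will reach it. The expected step is a 4.4-fold lower number from compound 2 to compound 3 (0.64 log units; beyond the scatter). The estimate for compound 3 in this assay is 600 nM, with a range from 200 nM to 2000 nM.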

Compound 3, half-maximal inhibitory concentration: 43100 nM
Beside the measured number, compound 3's estimate is 72-fold (1.86 log units) below it, outside the stated range (above it).
By their numbers in this assay, from the lowest: compound 1; then compound 2; then compound 3.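

The step of a 16-fold higher number from compound 2 to compound 3 (1.22 log units; beyond the scatter) runs opposite to the return toward compound 1 that the first pair seemed to allow: in this assay, taking away 1-carboxy-2-methylbutyl and putting in 1-(hydroxymethyl)ethyl carried the series further from compound 1, not closer to it. The step of a 180-fold higher number from compound 1 to compound 3 (2.25 log units; beyond the scatter) shows that this amide-type nitrogen can carry far more of the series' spread than the first pair revealed, and that the group on it can move the number a long way while the shared core stays the same; among these three compounds, the 4-heavy-atom group gives the highest number and the 8-heavy-atom group lies in the middle, so the order does not follow the size of the group alone, given that 2-(dimethylamino)ethyl gives the lowest. Nothing available here accounts for this order.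

The three compounds cannot say whether the low number of compound 1 depends on the dimethylamino group itself, which a 2-(diethylamino)ethyl, a pyrrolidine or a plain 2-aminoethyl chain would test. Nor can they separate the carboxylic acid of compound 2 from its branched sec-butyl chain, which a simple carboxymethyl group or a longer hydroxyalkyl chain would begin to do.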